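Chain Extension in a Series of Aminoalcohol Methyltransferase Inhibitors

The source may report more compounds than this note shows. Statements on the series, on what has been measured and on what is new or still open speak of the compounds shown alone.

The account concerns two aminoalcohols measured in an assay on isolated protein for inhibition of Phenylethanolamine N-methyltransferase (Bos taurus) (a lower number here means a stronger inhibitor, a higher number a weaker inhibitor), and one more compound that awaits measurement. Compound 1 `CCCCCCC(O)CN` gives 109000 nM in this assay. Compound 2 `CCCCCC(C)(O)CN` gives 669000 nM, the higher of the two numbers; its nearest neighbour is compound 1, whose number is lower by an amount beyond the usual scatter. The two measured structures differ in more than one place, so only their two values can be compared, not a single step.

Compound 3 `CCCCCCC(C)(O)CN` is derived from compound 2 by the change (methyl in place of hydrogen on a saturated chain carbon, six bonds along the chain from an oxygen on a saturated carbon), that is, methyl in place of hydrogen on a saturated chain carbon, six bonds along the chain from an oxygen on a saturated carbon. For the measured compounds named here, no measured pair of compounds shows this change on its own, so there is no precedent to lean on. A small step in this assay is expected, downward if anything, but one that may well stay within the scatter. The estimate for compound 3 is 400000 nM, within a range from 150000 nM to 1200000 nM. The step this estimate implies is a 1.7-fold lower number from compound 2 to compound 3 (0.22 log units; within the scatter).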

Compound 3, half-maximal inhibitory concentration: 664000 nM
For compound 3 the middle estimate is 1.7-fold (0.22 log units) below the measured one; the measured number falls inside the stated range.
By their numbers in this assay, from the lowest: compound 1; then compounds 3 and 2 (each within the scatter of the next).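

In this assay, methyl in place of hydrogen on a saturated chain carbon, six bonds along the chain from an oxygen on a saturated carbon, gives a 1.0-fold lower number from compound 2 to compound 3 (0.00 log units; within the scatter), so this added carbon leaves no readable mark at this position in compound 2. The same pair of structures does not settle the matter for every place on the chain: methyl in place of hydrogen on a saturated chain carbon bound to an oxygen on a saturated carbon and two saturated chain carbons gives a 6.1-fold higher number from compound 1 to compound 3 (0.78 log units; beyond the scatter), and that step, unlike the first, is beyond the scatter, though it rests on this single pair. Nothing at hand accounts for the contrast between these two places on the chain.

The compounds shown leave open whether the tolerance seen for compound 3 extends to an ethyl, a propyl or a longer chain at the position six bonds along the chain. They also leave open whether a group of another kind there, such as a hydroxyl or a carboxylic acid, would shift the number in this assay beyond the scatter.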